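Chloro for acetyl on a urea in a whole-organism rice assay

A few compounds are considered here, and "the series" means these few. Any claim that something is new, unique, unknown or untested is made for them only; others in the source may bear on it.

The measured compounds and their values:
Compound 1, `Cc1ccccc1NC(=O)N[C@H](C)c1ccccc1`, gives 100% in an ADME assay on the whole organism with Oryza sativa as the target, tested at 0.1 uM; on this read-out lower numbers stand for a stronger effect and higher numbers for a weaker effect at the one concentration tested.
Compound 2, `CCc1ccccc1NC(=O)N[C@H](C)c1ccccc1`, gives 101% in this assay.
Compound 3, `CC(=O)c1ccccc1NC(=O)N[C@H](C)c1ccccc1`, gives 96% in this assay.

Among these three, compound 3 has the lowest number, but its neighbours are close: the step of a number 4 percentage points lower from compound 1 to compound 3 (within the scatter) and the step of a number 5 percentage points lower from compound 2 to compound 3 (within the scatter) both lie within the scatter, as does the step of a number 1 percentage points higher from compound 1 to compound 2 (within the scatter). The three compounds therefore cannot be told apart on this read-out.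

Compound 4, `C[C@@H](NC(=O)Nc1ccccc1Cl)c1ccccc1`, has not yet been measured. It differs from compound 3 in one place: chloro in place of acetyl on an aromatic carbon. The change sits on an aromatic carbon of a six-membered aromatic ring of carbon only, ortho to a large group.

Among the compounds with values here, no measured step introduces a chloro group, so none bears directly on this change. The steps that touch the same position, acetyl in place of methyl and acetyl in place of ethyl, were both within the scatter. On that basis no step beyond the scatter is expected, and the step of a number 3 percentage points higher from compound 3 to compound 4 (within the scatter) is an estimate of no real change. Compound 4 is accordingly expected to give 99%, with a range from 88% to 108%.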

Compound 4, a percentage reported as activity, at one concentration (the size of the read-out at that concentration, not a potency): 101%
Compound 4: middle estimate off by 2 percentage points, on the low side; low and high end bracket the measured number.
By their numbers in this assay, from the lowest: compounds 3, 1, 2 and 4 (each within the scatter of the next).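

At this position on the aromatic ring, chloro now joins methyl, ethyl and acetyl, and this assay still does not separate them: chloro in place of acetyl gives a number 5 percentage points higher from compound 3 to compound 4 (within the scatter) while chloro in place of ethyl gives no change at the digits printed from compound 2 to compound 4 (within the scatter) and chloro in place of methyl gives a number 1 percentage points higher from compound 1 to compound 4 (within the scatter). A single chlorine atom, with no hydrogen-bond acceptor counted where acetyl has one, therefore reads the same as the three groups built on carbon, so across these four compounds the choice of group at this position leaves the read-out flat at the one concentration tested. No measurement is at hand that could explain this flat result.

As far as these compounds go, whether an amine, a carboxylic acid or a longer chain at this position would give a number beyond the scatter stays open. So does whether changes elsewhere in the shared core would count for more than changes here.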